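Trimming the amine side chain of a topoisomerase inhibitor

A few compounds are considered here, and "the series" means these few. Any claim that something is new, unique, unknown or untested is made for them only; others in the source may bear on it.

Of the compounds shown here, two have been measured so far in an assay on isolated protein for inhibition of DNA topoisomerase 1 (Homo sapiens), with a stated time of 15 min; on this read-out higher numbers stand for weaker inhibition and lower numbers for stronger inhibition. Compound 1 `O=C(O)c1cn(Cc2ccc(-n3cccn3)cc2)c2cc(N3C[C@H]4CCNC[C@H]4C3)c(F)cc2c1=O` gives 31300 nM in this assay, the lower of the two numbers. Compound 2 `CNC[C@@H]1CCN(c2c(F)cc3c(=O)c(C(=O)O)cn(Cc4ccc(-c5ccccc5)cc4)c3c2OC)C1` gives 155000 nM in this assay, a number that lies beyond the scatter above that of compound 1, but the two structures differ in several places at once, so nothing is read from that gap for a single change.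

Compound 3 `O=C(O)c1cn(Cc2ccc(-n3cccn3)cc2)c2cc(NC[C@H]3CCNC3)c(F)cc2c1=O` has not been measured. It differs from compound 1 by a group of 7 heavy atoms (5 carbon, 2 nitrogen; one five-membered non-aromatic ring with 1 hetero atom) in place of a group of 9 heavy atoms (7 carbon, 2 nitrogen; one five-membered non-aromatic ring with 1 hetero atom, one six-membered non-aromatic ring with 1 hetero atom), on an aromatic carbon. Going by the values given here, no step of this kind has been measured, so the size of the step is open; the authors expect a small change, if any, most likely toward a weaker inhibition, and possibly within the scatter. For compound 3 the estimated step is a 1.4-fold higher number from compound 1 to compound 3 (0.16 log units; within the scatter). Compound 3 is therefore expected to give about 45000 nM in this assay, within a range from 15000 nM to 150000 nM.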

Compound 3, half-maximal inhibitory concentration: 187000 nM
The estimate for compound 3 lay 4.2-fold (0.62 log units) below the measured number; measured number above the stated range.
By their numbers in this assay, from the lowest: compound 1; then compounds 2 and 3 (each within the scatter of the next).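

Going by these compounds alone, compound 1 and compound 3 give the first comparison that differs in one place, on an aromatic carbon ortho to a fluoro group. In this assay, exchanging the two-ring group of compound 1 for ((pyrrolidin-3-yl)methyl)amino gives a 6.0-fold higher number from compound 1 to compound 3 (0.78 log units; beyond the scatter), so inhibition at this position does change with the amine group attached, and the change is beyond the scatter. The entering group has 2 hydrogen-bond donors against 1 in the leaving group, and 1 defined stereocentre against 2, but no measurement shown bears on what lies behind the step.

On these data alone, whether a piperazine or a (piperidin-3-yl)amino group at this position would stay closer to compound 1 remains open. So does whether the step would keep its size with another group in place of the 4-(pyrazol-1-yl)benzyl group on the shared core.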